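Compound 3 and a Pyrrolidine Amide in Mice

A few compounds are considered here, and "the series" means these few. Any claim that something is new, unique, unknown or untested is made for them only; others in the source may bear on it.

In a functional assay on the whole organism for inhibition, with Mus musculus as the target (a higher number here means that more compound is needed for the effect, a lower number that less compound is needed), compound 3 (`CCCCOC(=O)Nc1cccc2c1CN(C)CC2c1ccccc1`) gives 4 mg/kg. Compound 1 (`CN1Cc2c(N)cccc2C(c2ccc(Cl)cc2)C1`) gives 1.6 mg/kg, a lower number than that of compound 3 and one that lies beyond the scatter. Compound 2 (`CC(C)c1ccc(C2CN(C)Cc3c(N)cccc32)cc1`) is reported only as > 80 mg/kg, which is a limit and not a number. Compound 3 therefore has the higher of the two actual numbers available.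

The next compound, compound 4 (`CN1Cc2c(NC(=O)CN3CCCC3)cccc2C(c2ccccc2)C1`), has not been measured. It carries (pyrrolidin-1-yl)methyl in place of butoxy on a carbonyl carbon, so the butoxycarbonyl group becomes ((pyrrolidin-1-yl)methyl)carbonyl.

Within the data shown here, only one measured step is available, an at least 50-fold higher number from compound 1 to compound 2 (1.69 log units; beyond the scatter). That step is large, but it exchanges chloro for isopropyl on an aromatic carbon and leaves the carbonyl group out of play. It gives no size for the present change, and it shows only that one replacement can move the number strongly in this assay. No direction can be drawn from it, so the expected step of a 1.3-fold higher number from compound 3 to compound 4 (0.10 log units; within the scatter) is modest, with wide uncertainty either way. For compound 4 the estimated value is 5 mg/kg, with an expected range from 1.2 mg/kg to 25 mg/kg.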

Compound 4, dose for half-maximal effect: 39 mg/kg
Estimate against measurement, compound 4: 7.8-fold (0.89 log units) below; the measured number lies above the stated range.
By their numbers in this assay, from the lowest: compound 1; then compound 3; then compound 4. At a limit, above all of these: compound 2.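

Replacing butoxy with (pyrrolidin-1-yl)methyl on this carbonyl carbon gives a 9.8-fold higher number from compound 3 to compound 4 (0.99 log units; beyond the scatter) in this assay. Among these compounds, the only earlier step concerned a group on an aromatic carbon, so this is the first sign that the group on the carbonyl carbon, with its amide-type nitrogen, also moves the number beyond the scatter, here towards more compound being needed. The two groups count alike for hydrogen-bond donors and acceptors and neither carries a net charge, so these counts do not separate them, and nothing measured here gives a cause for the step.

The compounds shown leave open whether the step follows from the five-membered ring, from the nitrogen or from the loss of the butoxy oxygen, a question that a dimethylamino group on the same methyl or a plain pentyl chain on the carbonyl carbon could help to answer. From the compounds shown here alone, it also remains open whether the same replacement would have a similar effect with chloro on the phenyl ring, as in compound 1.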